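The compounds below may be only part of what the source reports. "The series", "measured", "known", "first", "only" and "open" are said of these compounds alone.

In an ADME assay on L1210/0 cells (Mus musculus) for cytotoxicity, with a stated time of 48 h (on this read-out higher numbers stand for weaker inhibition and lower numbers for stronger inhibition), compound 1 (`O=C1O/C(=C\Cn2cc(Cl)c(=O)[nH]c2=O)C(OCc2ccccc2)=C1OCc1ccccc1`) gives 12200 nM. Compound 2 (`CC1(C)[C@@H](CCCO)C[C@H]1n1nnc2c(N)nc(N)nc21`) stands at the limit of > 200000 nM in this assay, at which 1 of the 2 values shown sits. Its reading of > 200000 nM is a limit of the assay and not a number.

Compound 3 (`CC1(C)[C@@H](CCCO)C[C@H]1n1nnc2c(Cl)nc(N)nc21`) departs from compound 2 in one place: chloro in place of amino on an aromatic carbon. Chloro takes the place of amino on an aromatic carbon of a six-membered aromatic ring with 2 nitrogen, part of a fused or bridged system of two rings. Within the data shown here, no measured pair in this assay shows this change, so the expectation rests on the structural change alone. A moderate move towards stronger inhibition is expected, with the reading possibly remaining at the limit. The expected size of the change is an at least 2.2-fold lower number from compound 2 to compound 3 (0.34 log units; beyond the scatter). Compound 3 is expected to remain weaker than compound 1 at 12200 nM. Compound 3 is estimated at 90000 nM, within an expected range of 20000 nM to 200000 nM.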

Compound 3, half-maximal inhibitory concentration: > 200000 nM
Compound 3: no number, only a limit; the forecaster's own chance of this, stated with the estimate: 45%; middle value at least 2.2-fold (0.34 log units) from the limit.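

No step can be read from compound 2 to compound 3, as both readings in this assay are limits of the assay and not numbers: the limit of > 200000 nM in this assay, at which 2 of the 3 values shown sit.

The compounds shown leave open how far chloro in place of amino on an aromatic carbon shifts inhibition, if it does so at all.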